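Replacing 3-methoxyazetidin-1-yl with amino on the carbonyl carbon

This account rests on a few compounds, and the source may have more. Where it says the series, first, only, none or still open, it means among the compounds named here.

Compound 1 `CNC(=O)/C=C/c1ccncc1-c1ccc2ccccc2c1`: > 10000 nM, a limit
Compound 2 `O=C(O)/C=C/c1ccncc1-c1ccc2ccccc2c1`: > 10000 nM, a limit
Compound 3 `COC1CN(C(=O)/C=C/c2ccncc2-c2ccc3ccccc3c2)C1`: > 10000 nM, a limit

In a functional assay on KB cells (Homo sapiens) for inhibition, read by sulforhodamine B assay, with a stated time of 72 h (on this read-out higher numbers stand for weaker inhibition of growth and lower numbers for stronger inhibition of growth), compound 3 stands only at a limit, not at a number. The other two compounds stand there as well: the limit of > 10000 nM in this assay, at which 3 of the 3 values shown sit. Compound 4 `NC(=O)/C=C/c1ccncc1-c1ccc2ccccc2c1` carries amino in place of 3-methoxyazetidin-1-yl on a carbonyl carbon. Two measured changes at the same carbonyl carbon bear on this: a step that the two limits leave unreadable from compound 1 to compound 3 and a step that the two limits leave unreadable from compound 2 to compound 3. Neither gives a size to carry over, so no step beyond the scatter is expected in either direction, and another limit is the likeliest outcome. The expected step is a step that the limit leaves unreadable from compound 3 to compound 4. For compound 4 the estimated value is 15000 nM, with an expected range of 6000 nM to 40000 nM.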

Compound 4, concentration for 50% growth inhibition: > 10000 nM
Compound 4: a limit, no number; the forecaster's own chance of this, stated with the estimate: 90%; the middle value lies beyond the limit too.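

Compound 4 sits at a limit, as do compound 1, compound 2 and compound 3, so no step among these compounds can be read: the limit of > 10000 nM in this assay, at which 4 of the 4 values shown sit.
In this assay the compounds shown leave open whether the groups on this carbonyl carbon differ in growth inhibition at all.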